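Hydrogen in place of chloro at the assay limit

The source may report more compounds than this note shows. Statements on the series, on what has been measured and on what is new or still open speak of the compounds shown alone.

In a functional assay on HL-60 cells (Homo sapiens) for antiproliferative activity, read by MTT assay, with a stated time of 72 h (on this read-out lower numbers stand for stronger inhibition and higher numbers for weaker inhibition), compound 3 `COc1cc(-c2ncnn2-c2ccc(Cl)cc2)cc(OC)c1OC` gives > 10000 nM as a limit, not a number. Compound 1 `COc1cc(-c2ncnn2-c2cccc(N)c2)cc(OC)c1OC` gives > 10000 nM as a limit too. Compound 2 `COc1cc(-c2ncnn2-c2ccc([N+](=O)[O-])cc2)cc(OC)c1OC` gives > 10000 nM as a limit too. Compound 3 therefore has no exact number to stand on, and neither of the other two offers one. Compound 4 `COc1cc(-c2ncnn2-c2ccccc2)cc(OC)c1OC` differs from compound 3 by a single change hydrogen in place of chloro on an aromatic carbon that puts hydrogen in place of chloro on an aromatic carbon, turning 4-chlorophenyl into phenyl. The measured steps a step that the two limits leave unreadable from compound 2 to compound 3 and a step that the two limits leave unreadable from compound 1 to compound 3 are the nearest guides, yet neither has a readable size. With the limit of > 10000 nM in this assay, at which 3 of the 3 values shown sit, as the whole of the evidence, no step beyond the scatter, in either direction, is expected in this assay for this change. The expected outcome is a step that the limit leaves unreadable from compound 3 to compound 4 and it may well be a limit again. The estimate for compound 4 is 12000 nM with an expected range from 4000 nM to 40000 nM as its likely span.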

Compound 4, half-maximal inhibitory concentration: > 10000 nM
Compound 4 was reported as a limit; the forecaster's own chance of this, stated with the estimate: 80%; the middle value lies beyond the limit too.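

In this assay compound 4 gives > 10000 nM, a limit and not a number, so its steps from compound 1, compound 2 and compound 3 cannot be read. The compounds shown leave open how these four truly differ in activity, and what change would give a measurable value: the limit of > 10000 nM in this assay, at which 4 of the 4 values shown sit.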